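This account rests on a few compounds, and the source may have more. Where it says the series, first, only, none or still open, it means among the compounds named here.

In a functional assay on BV-2 cells (Mus musculus), read by Griess assay (on this read-out higher numbers stand for weaker inhibition and lower numbers for stronger inhibition), compound 1 (`CO[C@]1(C)CC[C@@H](OC(C)=O)[C@@H]2[C@@](C)(C[C@H](OC(C)=O)C3=CC(=O)OC3)[C@H](C)C[C@H](OC(C)=O)[C@]21COC(C)=O`) gives 45500 nM and compound 2 (`CC[C@H](C)C(=O)O[C@@H](C[C@@]1(C)[C@H](C)C[C@H](O)[C@]2(C)[C@@H]1CCC[C@H]2C(=O)OC)C1=CC(=O)OC1`) gives 45000 nM. These two values lie within the usual scatter of each other, so compound 2 stands level with compound 1. Compound 3 (`C/C=C(\C)C(=O)O[C@@H](C[C@@]1(C)[C@H](C)C[C@H](O)[C@]2(C)[C@@H]1CCC[C@H]2C(=O)OC)C1=CC(=O)OC1`) carries 1-methylprop-1-en-1-yl in place of sec-butyl on a carbonyl carbon. Among the compounds with values here, no measured pair shows the size of such a change, so no shift beyond the scatter is expected in this assay. The estimated change is a 1.2-fold lower number from compound 2 to compound 3 (0.07 log units; within the scatter). Compound 3 is expected at 38000 nM, with an estimated range of 17000 nM to 80000 nM.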

Compound 3, half-maximal inhibitory concentration: 25800 nM
Beside the measured number, compound 3's estimate is 1.5-fold (0.17 log units) above it; the measured number falls inside the stated range.
By their numbers in this assay, from the lowest: compounds 3, 2 and 1 (each within the scatter of the next).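

In this assay the step of a 1.7-fold lower number from compound 2 to compound 3 (0.24 log units; within the scatter) shows that this carbonyl carbon takes 1-methylprop-1-en-1-yl, with its double bond and without the defined stereocentre of sec-butyl, with no shift beyond the scatter. Within the data shown here, this is the first exchange at this position that can be read, and it leaves the two compounds level. No evidence is at hand that bears on this result. The compounds shown leave open whether a longer chain, a phenyl ring or an amine on this carbonyl carbon would move the number beyond the scatter.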